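From Pyridin-3-yl to 2-Methylphenyl: An Expected Step

A few compounds are considered here, and "the series" means these few. Any claim that something is new, unique, unknown or untested is made for them only; others in the source may bear on it.

Of the compounds shown here, three built on a shared core have been measured in an assay on CHO cells for displacement of a labelled ligand from Alpha-2B adrenergic receptor (Homo sapiens); a higher number here means a weaker inhibitor, a lower number a stronger inhibitor. Compound 1 `CC(Oc1ccccc1-c1ccc([N+](=O)[O-])cc1)C1=NCCN1` gives 501 nM. Compound 2 `CC(Oc1ccccc1-c1cccnc1)C1=NCCN1` gives 933 nM, and compound 3 `CC(Oc1ccccc1-c1ccccc1)C1=NCCO1` gives 10000 nM. Among these three numbers compound 2 holds the second highest. Its nearest neighbour is compound 1, whose number lies within the usual scatter of that of compound 2, so no order between the two can be read. Its furthest is compound 3, whose number sits clearly beyond the scatter and higher, so compound 3 is the weaker inhibitor of that pair. Compound 3 differs from compound 2 in more than one place, so the gap cannot be tied to a single change.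

The compound not yet measured is compound 4 `Cc1ccccc1-c1ccccc1OC(C)C1=NCCN1`. It differs from compound 2 in one place: 2-methylphenyl in place of pyridin-3-yl on an aromatic carbon. Among the compounds with values here, no pair of measured compounds differs by just this exchange, so there is no measured step to lean on. Within the data shown here, the only hint is compound 1, which carries its own carbon-only ring and gives 501 nM, within the scatter of compound 2. The step from compound 2 to compound 4 is therefore expected to be small, a 1.3-fold lower number from compound 2 to compound 4 (0.12 log units; within the scatter), and not beyond the scatter in either direction. For compound 4 the estimate in this assay is 700 nM, with a range from 200 nM to 3000 nM.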

Compound 4, inhibition constant: 832 nM
The estimate for compound 4 lay 1.2-fold (0.08 log units) below the measured number, within the range that was stated.
By their numbers in this assay, from the lowest: compounds 1, 4 and 2 (each within the scatter of the next); then compound 3.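

In this assay, placing 2-methylphenyl in place of pyridin-3-yl on an aromatic carbon gives a 1.1-fold lower number from compound 2 to compound 4 (0.05 log units; within the scatter), the first step measured at this position with only one part of the molecule changed. The ring nitrogen and the hydrogen-bond acceptor counted on pyridin-3-yl are gone, and a ring of carbon only carrying a methyl group has entered, yet the two numbers cannot be told apart, so at this position this assay does not separate these two rings. Within the data shown here, nothing measured so far gives a reason for this closeness.

Every group at this position in the compounds shown is a six-membered aromatic ring, so it remains open whether the number would stay in the same range with a carboxylic acid, an amine or a longer alkyl chain in that place. Going by these compounds, it also remains open whether the same exchange would read the same way on a different core, and what the change in the other ring of compound 3 contributes on its own, since that compound differs from the others in more than one place.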